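Propyl Gives Way to Methoxy on the Aromatic Ring

The source may hold more compounds than are shown below. What is called first, only, known or untested is meant among the compounds shown, and "the series" means these compounds.

Measured so far in a functional assay on HepG2 cells (Homo sapiens) for inhibition, read by MTT assay, with a stated time of 72 h; on this read-out lower numbers stand for stronger inhibition and higher numbers for weaker inhibition:
compound 1 `O=C(Nc1ccccc1)C1CCN(C/C=C/c2ccccc2)CC1` gives 90900 nM
compound 2 `CCc1ccc(NC(=O)C2CCN(C/C=C/c3ccccc3)CC2)cc1` gives 23300 nM
compound 3 `CCCc1ccc(NC(=O)C2CCN(C/C=C/c3ccccc3)CC2)cc1` gives 9410 nM

Compound 3 stands lowest of the three, and its steps to both others lie beyond the scatter. Compound 4 `COc1ccc(NC(=O)C2CCN(C/C=C/c3ccccc3)CC2)cc1` carries methoxy in place of propyl on an aromatic carbon, a change counted as methoxy in place of propyl on an aromatic carbon here. Among the measured compounds shown here, the steps that bear on it are a 3.9-fold lower number from compound 1 to compound 2 (0.59 log units; beyond the scatter) with ethyl and a 9.7-fold lower number from compound 1 to compound 3 (0.98 log units; beyond the scatter) with propyl and a 2.5-fold lower number from compound 2 to compound 3 (0.39 log units; beyond the scatter) from ethyl to propyl, all modest. None of them tests methoxy, so only a modest move to a higher number is expected. The estimate is a 3.0-fold higher number from compound 3 to compound 4 (0.47 log units; beyond the scatter) in this assay as an expected modest rise. For compound 4 the estimated value is 28000 nM with an expected range of 9000 nM to 80000 nM overall.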

Compound 4, half-maximal inhibitory concentration: 88800 nM
For compound 4 the middle estimate is 3.2-fold (0.50 log units) below the measured one, outside the stated range (above it).
By their numbers in this assay, from the lowest: compound 3; then compound 2; then compounds 4 and 1 (each within the scatter of the next).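

In this assay methoxy at this place does not follow ethyl and propyl: the change gives a 9.4-fold higher number from compound 3 to compound 4 (0.97 log units; beyond the scatter) and, against ethyl, a 3.8-fold higher number from compound 2 to compound 4 (0.58 log units; beyond the scatter) while a 1.0-fold lower number from compound 1 to compound 4 (0.01 log units; within the scatter) means that methoxy and hydrogen cannot be told apart here. Lower numbers at this position therefore go with the two alkyl chains shown, not with every group placed there. Nothing available here accounts for this difference.

The compounds shown leave open whether a longer chain such as butyl would extend the run from ethyl to propyl. They also leave open whether ethoxy or an amine at this place would stand nearer propyl or methoxy.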